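The compounds below may be only part of what the source reports. "The series", "measured", "known", "first", "only" and "open" are said of these compounds alone.

Compound 1, `Oc1ccc(-c2nc3cc(F)ccc3s2)cc1O`: 1640 nM
Compound 2, `COc1cc(-c2nc3cc(F)ccc3s2)ccc1O`: 1040 nM

In a functional assay on HCC 2998 cells (Homo sapiens) for antiproliferative activity (a lower number here means a stronger inhibitor of growth, a higher number a weaker inhibitor of growth), compound 1 gives 1640 nM and compound 2 gives 1040 nM. Compound 2 shows the lower of the two numbers, but the step of a 1.6-fold lower number from compound 1 to compound 2 (0.20 log units; within the scatter) stays within the scatter, so no real difference between the two can be claimed. Compound 3, `COCOc1ccc(-c2nc3cc(F)ccc3s2)cc1OC`, differs from compound 2 by methoxymethyl in place of hydrogen on an oxygen on an aromatic ring. Among the measured compounds shown here, the only measured step that bears on this is the one from compound 1 to compound 2, where methyl replaced hydrogen on an oxygen on an aromatic ring, and that step was small: a 1.6-fold lower number from compound 1 to compound 2 (0.20 log units; within the scatter). Capping the remaining oxygen with a larger group is expected to behave similarly, giving a step of a 1.4-fold higher number from compound 2 to compound 3 (0.16 log units; within the scatter) that is not expected to exceed the scatter. For compound 3 the value in this assay is therefore estimated at 1500 nM, with a range of 500 nM to 4500 nM.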

Compound 3, concentration for 50% growth inhibition: 53500 nM
Estimate against measurement, compound 3: 36-fold (1.55 log units) below; measured number above the stated range.
By their numbers in this assay, from the lowest: compounds 2 and 1 (each within the scatter of the next); then compound 3.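

In this assay, the step of a 51-fold higher number from compound 2 to compound 3 (1.71 log units; beyond the scatter) shows that this oxygen tolerates change far less than the earlier comparison suggested: replacing the hydrogen of the hydroxy group with methoxymethyl costs much of the growth inhibition. Among the compounds shown here, the only earlier step, a methyl added on an oxygen in the step of a 1.6-fold lower number from compound 1 to compound 2 (0.20 log units; within the scatter), stayed within the scatter, so a small change on one oxygen says little about a larger one on the remaining oxygen. No measured data shown here explain this large step.

The compounds shown cannot separate the loss of the free hydroxy hydrogen from the size of the methoxymethyl group. A methyl or an ethyl on this same oxygen would help to tell these two readings apart, and a longer chain ending in an amine would test how much more this position accepts.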